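Adding a Methoxy Group to the Central Ring

The source may report more compounds than this note shows. Statements on the series, on what has been measured and on what is new or still open speak of the compounds shown alone.

Compound 1 `COc1ccc(C(=O)c2cc(OC)c(OC)c(OC)c2)cc1NC(=O)/C=C/c1cc(OC)c(OC)c(OC)c1` gives 3900 nM in a functional assay on PC-3 cells (Homo sapiens) for cytotoxicity, read by MTT assay, with a stated time of 72 h; on this read-out lower numbers stand for stronger inhibition and higher numbers for weaker inhibition.
Compound 2 `COc1ccc(/C=C/C(=O)Nc2cc(C(=O)c3cc(OC)c(OC)c(OC)c3)ccc2OC)cc1` gives 11100 nM in this assay.

Among the compounds with values here, compound 1 holds the lowest of the two numbers so far; its nearest neighbour is compound 2, and the step of a 2.8-fold higher number from compound 1 to compound 2 (0.45 log units; beyond the scatter) lies beyond the scatter. Compound 3 `COc1cc(C(=O)c2cc(OC)c(OC)c(OC)c2)cc(NC(=O)/C=C/c2cc(OC)c(OC)c(OC)c2)c1OC` has not yet been measured. It differs from compound 1 in one place: methoxy in place of hydrogen on an aromatic carbon. Within the data shown here, the only measured step concerns a different part of the molecule, the aryl group on the double-bonded chain, so no step directly bears on the change from compound 1 to compound 3. On the central ring, the data hold no comparison at all. With nothing to point either way, a step within the scatter of this assay is the plain expectation, with a wide range to allow for the absence of any guide. Compound 3 is therefore estimated at 3500 nM, between 1200 nM and 10000 nM, which means an expected step of a 1.1-fold lower number from compound 1 to compound 3 (0.05 log units; within the scatter).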

Compound 3, half-maximal inhibitory concentration: 4800 nM
Compound 3: the middle estimate sits 1.4-fold (0.14 log units) below what was measured; measured number inside the range.
By their numbers in this assay, from the lowest: compounds 1 and 3 (each within the scatter of the next); then compound 2.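

In this assay, methoxy in place of hydrogen on this aromatic carbon, ortho to a methoxy group and meta to two large groups, gives a 1.2-fold higher number from compound 1 to compound 3 (0.09 log units; within the scatter) and so leaves the number within the scatter of the parent. Within the data shown here, until now the only measured change lay on the aryl group of the chain, where the step of a 2.8-fold higher number from compound 1 to compound 2 (0.45 log units; beyond the scatter) lies beyond the scatter, whereas this result is the first reading from the ring that carries the carbonyl and the amide nitrogen, and here the added methoxy produces no step that can be told from the scatter. No measurement at hand offers an explanation for this outcome.

The compounds shown leave open whether an amine, a carboxylic acid or a longer chain such as ethoxy on this same aromatic carbon would also stay within the scatter of compound 1. They also leave open whether the added methoxy would give a similar step on compound 2, with its 4-methoxyphenyl group, and whether the result would hold on cells other than those of this assay.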